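Isopentyl to (tert-butyl)carbonyl on the aromatic oxygen

The source may report more compounds than this note shows. Statements on the series, on what has been measured and on what is new or still open speak of the compounds shown alone.

Within the data shown here, compound 2 `CC(C)CCOc1ccc2oc(/C=C/[S+](C)[O-])cc(=O)c2c1` gives the only number in a functional assay on DLD-1 cells (Homo sapiens) for cytotoxicity, with a stated time of 48 h (on this read-out higher numbers stand for weaker inhibition and lower numbers for stronger inhibition), namely 4100 nM. Compound 1 `C[S+]([O-])/C=C/c1cc(=O)c2cc(O)ccc2o1`, which carries a hydrogen on that oxygen, is reported in this assay only as a limit of the assay, > 10000 nM. Among the measured compounds shown here, the single measured step, an at least 2.4-fold lower number from compound 1 to compound 2 (0.38 log units; beyond the scatter), therefore lowers the number, and its stated size rests on (the limit of > 10000 nM in this assay, at which 1 of the 2 values shown sits). Compound 3 `C[S+]([O-])/C=C/c1cc(=O)c2cc(OC(=O)C(C)(C)C)ccc2o1` differs from compound 2 by (tert-butyl)carbonyl in place of isopentyl on an oxygen on an aromatic ring. For the measured compounds named here, only the step from compound 1 to compound 2 bears on this change, and it shows what happens when a carbon group replaces hydrogen on that oxygen, not how two such groups compare; both groups here lack a ring and carry the same number of carbons. The expected step in this assay is a 1.5-fold higher number from compound 2 to compound 3 (0.17 log units; within the scatter), within the scatter. Compound 3 is estimated at 6000 nM, with a range from 2500 nM to 15000 nM.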

Compound 3, half-maximal inhibitory concentration: 8000 nM
Compound 3: the middle estimate sits 1.3-fold (0.12 log units) below what was measured; the range from low to high includes it.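

On an oxygen on an aromatic ring, (tert-butyl)carbonyl in place of isopentyl gives a 2.0-fold higher number from compound 2 to compound 3 (0.29 log units; within the scatter) in this assay, so this assay does not separate the two groups, even though the entering group brings a carbonyl that the leaving group lacks. The change from hydrogen to (tert-butyl)carbonyl on that oxygen gives an at least 1.2-fold lower number from compound 1 to compound 3 (0.09 log units; that floor lies within the scatter), and unlike the floor of the step from hydrogen to isopentyl, this floor does not clear the scatter. Going by these compounds, that step rests on a limit of the assay, so its true size stays unknown: the limit of > 10000 nM in this assay, at which 1 of the 3 values shown sits.

The compounds shown leave open whether a longer chain, a chain ending in an amine or a carboxylic acid on that oxygen would shift the number beyond the scatter. They also leave open what a phenyl ring in that place would do.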